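The compounds below may be only part of what the source reports. "The series", "measured", "known", "first", "only" and "open" are said of these compounds alone.

Compound 1 `Cc1ccccc1S(=O)(=O)N1CCN(c2ccc(C(=O)NCc3cccs3)nn2)CC1` was measured in an ADME assay on microsomes from liver (Homo sapiens), read by LC-MS, using NADPH, tested at 10 uM (a higher number here means that the liver removes a larger share of the compound in one pass, a lower number that the liver removes a smaller share), and gives 0.92. Two companions set the frame. Compound 2 `Cc1ccccc1S(=O)(=O)N1CCN(c2cnc(C(=O)NCc3ccc(F)cc3)cn2)CC1` gives 0.95 in this assay, and compound 3 `O=C(NCc1ccccc1)c1ccc(N2CCC(S(=O)(=O)c3cccc(Cl)c3Cl)CC2)nn1` gives 0.61. Among the three numbers compound 1 stands second highest; the number for compound 2 lies within the usual scatter of it, so the two cannot be told apart, while the number for compound 3 lies beyond the scatter and is the lowest of the set.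

Compound 4 `Cc1ccccc1S(=O)(=O)N1CCN(c2ccc(C(=O)NCc3cncs3)nn2)CC1` has not yet been measured. It differs from compound 1 in one place: 1,3-thiazol-5-yl in place of thiophen-2-yl on a saturated chain carbon bound to an amide-type nitrogen. Going by the values given here, no pair of measured compounds shares this change, so nothing in the data shows how large a step it brings. The hetero atom count of the group grows, but the rest of compound 1 is kept whole, and the high number of compound 1 leaves little room upward. The step from compound 1 to compound 4 is therefore expected to be small, a number 0.020 lower from compound 1 to compound 4 (within the scatter), not beyond the scatter in either direction. Compound 4 is expected to give about 0.9 in this assay, with a likely range from 0.8 to 0.97.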

Compound 4, hepatic extraction ratio: 0.59
The estimate for compound 4 lay 0.31 above the measured number; the measured number lies below the stated range.
By their numbers in this assay, from the lowest: compounds 4 and 3 (each within the scatter of the next); then compounds 1 and 2 (each within the scatter of the next).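

In this assay, 1,3-thiazol-5-yl in place of thiophen-2-yl on a saturated chain carbon bound to an amide-type nitrogen brings a number 0.33 lower from compound 1 to compound 4 (beyond the scatter), so this place alone can move the read-out well beyond the scatter while the rest of compound 1 stays whole. The two groups have the same count of heavy atoms and differ in the ring only by a nitrogen that takes the place of a carbon, so a large step here comes from a change small in those counts. Nothing at hand bears on why the step is this large.

Going by these compounds, what a 1,3-oxazol-5-yl or a 1,3-thiazol-2-yl group would give in this place remains open. Also open, on these data alone, is whether the same change brings a step of this size on another core.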